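This account rests on a few compounds, and the source may have more. Where it says the series, first, only, none or still open, it means among the compounds named here.

Compound 1 `Nc1ccc(CNC(=O)CC2c3ccccc3N=C(N3CCCCC3)N2c2ccccc2)cc1`: 37100 nM
Compound 2 `CCN1C(N2CCCCC2)=Nc2ccccc2C1CC(=O)NCc1ccc(NS(=O)(=O)c2ccc(C)cc2)cc1`: 22300 nM

Both compounds were tested in a functional assay on KB cells (Homo sapiens) for inhibition, read by sulforhodamine B assay; a lower number here means a stronger inhibitor of growth, a higher number a weaker inhibitor of growth. Compound 2 gives 22300 nM, the smaller of the two numbers, and compound 1 gives 37100 nM; the two sit within the usual scatter of each other, so no real difference between them is established. Compound 1 and compound 2 differ from one another in more than one place, so no single structural step can be read from that pair.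

Compound 3 `Cc1ccc(S(=O)(=O)Nc2ccc(CNC(=O)CC3c4ccccc4N=C(N4CCCCC4)N3c3ccccc3)cc2)cc1` has not yet been measured. It differs from compound 2 in one place: phenyl in place of ethyl on an amine nitrogen in a ring. Among the compounds with values here, no measured pair shows this change on its own, so nothing here tells how large a step it makes. Within the data shown here, with only two numbers known, and those two within the scatter of each other, the change is expected to give no step beyond the scatter in either direction. Compound 3 is therefore estimated at 22000 nM, with a range from 8000 nM to 60000 nM. The step this estimate implies, a 1.0-fold lower number from compound 2 to compound 3 (0.01 log units; within the scatter), is expected to stay within the scatter.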

Compound 3, concentration for 50% growth inhibition: 3110 nM
Estimate against measurement, compound 3: 7.1-fold (0.85 log units) above, and the stated range ends above it.
By their numbers in this assay, from the lowest: compound 3; then compounds 2 and 1 (each within the scatter of the next).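

In this assay, within the data shown here, the amine nitrogen in the ring of the shared core proves sensitive to what it carries: phenyl in place of ethyl gives a 7.2-fold lower number from compound 2 to compound 3 (0.86 log units; beyond the scatter), the first step in this set that lies beyond the scatter. Among these compounds, a second change can now be read as well: with phenyl on that ring nitrogen in both compounds, (4-methylphenyl)sulfonyl in place of hydrogen on a nitrogen on an aromatic ring gives a 12-fold lower number from compound 1 to compound 3 (1.08 log units; beyond the scatter), so compound 3, the only compound here that carries both groups, is also the only one whose number stands clearly apart from the others. No measurement in hand gives a reason for either step.

As far as these compounds go, whether the gain needs an aromatic ring on the ring nitrogen stays open, since a benzyl group, a pyridyl ring or a longer chain such as butyl could be set against phenyl and ethyl there. Also open, from the compounds shown here alone, is whether phenyl would give a similar step with other groups on the far nitrogen, such as an acetyl group or a smaller methanesulfonyl group in place of (4-methylphenyl)sulfonyl.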